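The source may report more compounds than this note shows. Statements on the series, on what has been measured and on what is new or still open speak of the compounds shown alone.

Working notes on the series. Compound 1 `Cc1ccc(Cn2cc(CSc3nnc(-c4ccccc4)c(-c4ccccc4)n3)nn2)cc1` gives 22600 nM in a functional assay on PC-3 cells (Homo sapiens) for antiproliferative activity, read by MTT assay, with a stated time of 48 h; a lower number here means a stronger inhibitor, a higher number a weaker inhibitor. Compound 2 `Fc1ccc(Cn2cc(CSc3nnc(-c4ccccc4)c(-c4ccccc4)n3)nn2)cc1` gives 10600 nM in this assay, and the step of a 2.1-fold lower number from compound 1 to compound 2 (0.33 log units; beyond the scatter) is the only one here that lowers the number. Compound 3 `NS(=O)(=O)c1ccc(-n2cc(CSc3nnc(-c4ccccc4)c(-c4ccccc4)n3)nn2)cc1` does not reach a number in this assay: the reading for compound 3 is > 100000 nM, which is a limit of the assay, (the limit of > 100000 nM in this assay, at which 1 of the 3 values shown sits). Set against the two compounds carrying a 4-methylbenzyl or 4-fluorobenzyl group, compound 3 stands at the weak end, with an at least 4.4-fold higher number from compound 1 to compound 3 (0.64 log units; beyond the scatter) and an at least 9.4-fold higher number from compound 2 to compound 3 (0.97 log units; beyond the scatter).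

Compound 4 `c1ccc(-c2nnc(SCc3cn(Cc4ccc5ccccc5c4)nn3)nc2-c2ccccc2)cc1` is still to be measured in this assay. The change from compound 3 is (naphthalen-2-yl)methyl in place of 4-sulfamoylphenyl on an aromatic nitrogen. The two measured steps that bear on this place, from compound 1 and from compound 2 to compound 3, both raised the number by at least a modest amount when a 4-sulfamoylphenyl group replaced a substituted benzyl group; the present change runs the other way, toward a (naphthalen-2-yl)methyl group, so a drop beyond the scatter back into the range of compounds 1 and 2 is expected. For compound 4 the estimate in this assay is 15000 nM, with a range from 4000 nM to 60000 nM. This expectation amounts to a step of an at least 6.6-fold lower number from compound 3 to compound 4 (0.82 log units; beyond the scatter).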

Compound 4, half-maximal inhibitory concentration: > 100000 nM
Compound 4 was reported as a limit; the forecaster's own chance of this, stated with the estimate: 15%; at least 6.6-fold (0.82 log units) between middle value and limit.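

Compound 4 shows that keeping the saturated chain carbon on the aromatic nitrogen does not by itself hold the reading in this assay: with naphthalen-2-yl on that carbon, the number is higher than with the aryl groups of the two benzyl compounds (an at least 9.4-fold higher number from compound 2 to compound 4 (0.97 log units; beyond the scatter); an at least 4.4-fold higher number from compound 1 to compound 4 (0.64 log units; beyond the scatter)). The weak end of the series is therefore not confined to the 4-sulfamoylphenyl group, since a (naphthalen-2-yl)methyl group, carbon only, reaches it as well. The step linking compound 3 and compound 4 cannot be read, both readings being limits of the assay: the limit of > 100000 nM in this assay, at which 2 of the 4 values shown sit.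

Where compound 4 lies beyond its limit stays open, so no order can be set with compound 3. Also open, from the compounds shown here alone, is how an amine or a carboxylic acid on the benzyl ring, or a longer chain on the aromatic nitrogen, would read.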